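This account rests on a few compounds, and the source may have more. Where it says the series, first, only, none or still open, it means among the compounds named here.

Compound 1 `Nc1nc(SCc2cccc(Br)c2)c2ncn([C@@H]3O[C@H](CO)[C@@H](O)[C@H]3O)c2n1`: 2880 nM
Compound 2 `Nc1nc(SCCc2ccccc2)c2ncn([C@@H]3O[C@H](CO)[C@@H](O)[C@H]3O)c2n1`: 16200 nM

Among the measured compounds shown here, in an assay on isolated protein for binding affinity to Equilibrative nucleoside transporter 1 (Homo sapiens) (on this read-out lower numbers stand for stronger inhibition and higher numbers for weaker inhibition), compound 2 gives the higher of the two numbers, and the single measured step that reaches it is a 5.6-fold higher number from compound 1 to compound 2 (0.75 log units; beyond the scatter), modest yet beyond the scatter. Compound 3 `Nc1nc(SCc2ccccn2)c2ncn([C@@H]3O[C@H](CO)[C@@H](O)[C@H]3O)c2n1` differs from compound 2 by pyridin-2-yl in place of benzyl on a saturated chain carbon bound to a sulfur. For the measured compounds named here, no measured step matches this exact change; the one known step does show that altering the group on the sulfur-bound chain carbon moves this assay by a modest amount. Compound 3 is therefore expected to give a lower number, an estimated 5000 nM with a range from 1500 nM to 16000 nM, meaning a 3.2-fold lower number from compound 2 to compound 3 (0.51 log units; beyond the scatter).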

Compound 3, half-maximal inhibitory concentration: 34700 nM
Compound 3: middle estimate off by 6.9-fold (0.84 log units), on the low side; the whole stated range lies below it.
By their numbers in this assay, from the lowest: compound 1; then compound 2; then compound 3.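

In this assay, pyridin-2-yl in place of 3-bromophenyl on the saturated chain carbon bound to the sulfur gives a 12-fold higher number from compound 1 to compound 3 (1.08 log units; beyond the scatter), the largest step among these compounds. Pyridin-2-yl in place of benzyl gives a 2.1-fold higher number from compound 2 to compound 3 (0.33 log units; beyond the scatter), so the ring holding a nitrogen stands above both all-carbon rings here, and compound 2 no longer marks the top of the series. No supporting measurement accounts for this order. Open, as far as these compounds go, is how a plain phenyl, a 3-chlorophenyl or a pyridin-3-yl on that carbon would read, and so whether the bromine or the place of the ring nitrogen carries the gap.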